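The source may hold more compounds than are shown below. What is called first, only, known or untested is meant among the compounds shown, and "the series" means these compounds.

Working notes on the series. In a functional assay on ECV-304 cells (Homo sapiens) for cytotoxicity (on this read-out higher numbers stand for weaker inhibition and lower numbers for stronger inhibition), compound 1 `N#Cc1ccc(/C=C2\SC(=S)N(NS(=O)(=O)c3ccccc3)C2=O)cc1` gives > 50000 nM as a limit and not a number. Compound 2 `O=C1/C(=C/c2ccc(Cl)c(F)c2)SC(=S)N1NS(=O)(=O)c1ccccc1` gives > 50000 nM and this too is a limit. Compound 3 `O=C1/C(=C/c2ccc(Cl)c(Cl)c2)SC(=S)N1NS(=O)(=O)c1ccccc1` gives > 50000 nM as a limit as well, so it has no number of its own. It stands with the other two compounds, and the whole picture so far is the limit of > 50000 nM in this assay, at which 3 of the 3 values shown sit, with no measured value inside the range of this assay yet.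

The next structure is compound 4 `O=C1/C(=C/c2ccc(F)cc2F)SC(=S)N1NS(=O)(=O)c1ccccc1` and the change is 2,4-difluorophenyl in place of 3,4-dichlorophenyl on a double-bonded chain carbon bound to a double-bonded ring carbon with the rest of the shared core untouched. Going by the values given here, three measured steps bear on this change. They are a step that the two limits leave unreadable from compound 1 to compound 2 and a step that the two limits leave unreadable from compound 1 to compound 3 and also a step that the two limits leave unreadable from compound 2 to compound 3 and none of them has a size that can be carried over. Each swaps the substituents on the same phenyl group, and none has left the limit. No step beyond the scatter is therefore expected in this assay and no direction is favoured.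

The expected step is a number no higher from compound 3 to compound 4 (the limit leaves the size open) and no direction is read into it. The estimated value for compound 4 is 50000 nM with an expected range of 25000 nM to 100000 nM and a report as a limit once more is the likeliest outcome.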

Compound 4, half-maximal inhibitory concentration: > 50000 nM
Compound 4 was reported as a limit; the forecaster's own chance of this, stated with the estimate: 85%; the middle value lies on the limit itself.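

In this assay compound 4 gives > 50000 nM, a limit and not a number. The steps to compound 4 from compound 1, compound 2 and compound 3 therefore cannot be read. The compounds shown leave open whether any change on the phenyl group alters the read-out, as the series offers only one reading: the limit of > 50000 nM in this assay, at which 4 of the 4 values shown sit.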